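A few compounds are considered here, and "the series" means these few. Any claim that something is new, unique, unknown or untested is made for them only; others in the source may bear on it.

Compound 3, `COc1cc(NC(=O)Nc2cc(Nc3cccc(C(C)(C)C)c3)ncn2)cc(OC)c1`, was tested in a functional assay on NCI-H226 cells (Homo sapiens) for inhibition, read by MTT assay, with a stated time of 48 h, tested at 10 uM (on this read-out higher numbers stand for more inhibition at the one concentration tested (going by the name of the read-out) and lower numbers for less inhibition), and gave 40%. Two other compounds of the same series had been measured before it. Compound 1, `COc1cc(Br)ccc1Nc1cc(NC(=O)Nc2c(Cl)cccc2Cl)ncn1`, gave 43% in this assay, and compound 2, `COc1cc(NC(=O)Nc2cc(Nc3ccc(C)c(F)c3)ncn2)cc(OC)c1`, gave 39.7%. On these three numbers compound 3 stands second highest, but every gap is within the scatter: the step of a number 0.3 percentage points higher from compound 2 to compound 3 (within the scatter) is small, and compound 1 sits only a little above compound 3. The three compounds therefore cannot be ordered on the evidence at hand.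

The next compound, compound 4, `COc1cc(NC(=O)Nc2cc(Nc3ccc(Br)cc3OC)ncn2)cc(OC)c1`, carries a different group on the same nitrogen: 4-bromo-2-methoxyphenyl in place of 3-(tert-butyl)phenyl on a nitrogen on an aromatic ring. Among the compounds with values here, only one measured step bears on changes at this position, and it is a number 0.3 percentage points higher from compound 2 to compound 3 (within the scatter), which lies within the scatter. The data thus give no sign that swapping the group on this nitrogen moves the read-out by more than the scatter, and the expectation for compound 4 is accordingly flat. Compound 4 is expected to give 41% in this assay, with a range from 30% to 52%. The step this estimate implies, a number 1 percentage points higher from compound 3 to compound 4 (within the scatter), is expected to stay within the scatter.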

Compound 4, a percentage reported as inhibition, at one concentration (the size of the read-out at that concentration, not a potency): 25.7%
The estimate for compound 4 lay 15.3 percentage points above the measured number; measured number below the stated range.
By their numbers in this assay, from the lowest: compound 4; then compounds 2, 3 and 1 (each within the scatter of the next).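

In this assay, the group on a nitrogen on an aromatic ring proves able to move the read-out: 4-bromo-2-methoxyphenyl in place of 3-(tert-butyl)phenyl gave a number 14.3 percentage points lower from compound 3 to compound 4 (beyond the scatter) and in place of 3-fluoro-4-methylphenyl gave a number 14 percentage points lower from compound 2 to compound 4 (beyond the scatter) while the step between those two replaced groups had stayed within the scatter. With 4-bromo-2-methoxyphenyl held fixed, the amide-type nitrogen also proves responsive, as 3,5-dimethoxyphenyl in place of 2,6-dichlorophenyl gave a number 17.3 percentage points lower from compound 1 to compound 4 (beyond the scatter) in the same read-out. No measurement at hand accounts for either change.

The compounds shown do not separate the bromine from the methoxy group of 4-bromo-2-methoxyphenyl, a question that a plain 4-bromophenyl or 2-methoxyphenyl group on the same nitrogen would address. As far as these compounds go, it also remains open whether the difference between 2,6-dichlorophenyl and 3,5-dimethoxyphenyl on the amide-type nitrogen holds with 3-(tert-butyl)phenyl or 3-fluoro-4-methylphenyl on the other nitrogen, and how a basic amine such as a morpholine or a carboxylic acid on either aromatic ring would fare.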